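The compounds below may be only part of what the source reports. "The series", "measured", "known", "first", "only" and "open" are said of these compounds alone.

Compound 1 `COc1cc(-c2ncnn2-c2cccc(F)c2)cc(OC)c1OC` is tested in a functional assay on Jurkat cells (Homo sapiens) for antiproliferative activity, read by MTT assay, with a stated time of 72 h (a higher number here means a weaker inhibitor, a lower number a stronger inhibitor), where compound 1 gives > 10000 nM, a limit of the assay and not a number. Compound 2 `COc1ccc(-c2ncnn2-c2cc(OC)c(OC)c(OC)c2)cc1` gives a true reading of 50 nM. Compound 3 `COc1cc(-n2ncnc2-c2ccc(Cl)c(Cl)c2)cc(OC)c1OC` gives > 10000 nM, which is again a limit. The picture so far is therefore thin, and (the limit of > 10000 nM in this assay, at which 2 of the 3 values shown sit).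

The next compound, compound 4 `COc1cc(-c2ncnn2-c2ccc(Cl)cc2)cc(OC)c1OC`, keeps the core of compound 1 but has 4-chlorophenyl in place of 3-fluorophenyl on an aromatic nitrogen.

For the measured compounds named here, only one measured step is available as a guide: an at least 200-fold higher number from compound 2 to compound 3 (2.30 log units; beyond the scatter). That large step put 3,4-dichlorophenyl in place of 4-methoxyphenyl on an aromatic carbon, not on the aromatic nitrogen, so it bears on the present change only loosely. It does show that a chlorine-bearing phenyl can go with a reading at the limit.

Compound 1 already sits at > 10000 nM, so no step beyond the scatter is expected in this assay, and a real reading near the limit is the most that seems likely. The estimated change is a number no higher from compound 1 to compound 4 (the limit leaves the size open). For compound 4 the expected value is 10000 nM, with an estimated range of 2000 nM to 20000 nM.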

Compound 4, half-maximal inhibitory concentration: > 10000 nM
Compound 4 was reported as a limit; the forecaster's own chance of this, stated with the estimate: 70%; the middle value sits exactly at the limit.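

For the compounds shown here, compound 1 and compound 4 are both reported only as limits, and no step between them can be read. Most readings now sit at the same place: the limit of > 10000 nM in this assay, at which 3 of the 4 values shown sit. The compounds shown leave open whether 3-fluorophenyl and 4-chlorophenyl on the aromatic nitrogen differ at all in this assay.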